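The source may hold more compounds than are shown below. What is called first, only, known or untested is meant among the compounds shown, and "the series" means these compounds.

Working notes on the series. Among the compounds with values here, in an ADME assay for solubility, in simulated intestinal fluid, at pH 6.8 (a higher number here means a more soluble compound, a lower number a less soluble compound), compound 1 `O=C(CCSc1nc2c(c(=O)[nH]1)CCCC2)N[C@H]1CC[C@H](c2nnc(-c3ccccc3)o2)CC1` gives 8 ug/mL, the lowest of the three numbers so far, with compound 2 `O=C(N[C@H]1CC[C@H](c2nnc(-c3ccccc3)o2)CC1)[C@@H]1CCCN(Cc2nc3ccccc3c(=O)[nH]2)C1` at 43 ug/mL and compound 3 `O=C(C[C@H]1CCCN1Cc1nc2ccccc2c(=O)[nH]1)N[C@H]1CC[C@H](c2nnc(-c3ccccc3)o2)CC1` at 42 ug/mL. The gaps from compound 1 to these two both lie beyond the scatter.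

The next compound to read is compound 4 `O=C(CCSc1nccc(=O)[nH]1)N[C@H]1CC[C@H](c2nnc(-c3ccccc3)o2)CC1`, which keeps the rest of compound 1 and changes only on a sulfur whose other neighbours are saturated chain carbon: a group of 7 heavy atoms (4 carbon, 2 nitrogen, 1 oxygen; one six-membered aromatic ring with 2 hetero atoms) in place of a group of 11 heavy atoms (8 carbon, 2 nitrogen, 1 oxygen; one six-membered non-aromatic ring of carbon only, one six-membered aromatic ring with 2 hetero atoms), on a sulfur. The six-membered non-aromatic ring of carbon only is gone.

Within the data shown here, no measured pair differs in one place only, so the data give no direct size for this kind of step. The expectation in this assay is therefore a judgement from the structural change alone: a moderate rise, probably just beyond the scatter. The expected step is a 2.5-fold higher number from compound 1 to compound 4 (0.40 log units; beyond the scatter). For compound 4 the estimated value is 20 ug/mL, with an expected range of 8 ug/mL to 50 ug/mL.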

Compound 4, solubility: 53 ug/mL
Beside the measured number, compound 4's estimate is 2.7-fold (0.42 log units) below it, and the stated range ends below it.
By their numbers in this assay, from the lowest: compound 1; then compounds 3, 2 and 4 (each within the scatter of the next).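

Within the data shown here, the step of a 6.6-fold higher number from compound 1 to compound 4 (0.82 log units; beyond the scatter) in this assay is the first reading of a change in one place only, and it gives this position on a sulfur whose other neighbours are saturated chain carbon a measured size. The change removes the six-membered non-aromatic ring of carbon only, while the six-membered aromatic ring with 2 hetero atoms, the hydrogen-bond donor and acceptor counts and the absence of net charge stay the same in both groups. No measurement in hand gives a reason for the size of this step.

This single step cannot separate the loss of that ring from the accompanying drop in heavy atoms. From the compounds shown here alone, how an amine, a carboxylic acid or a longer chain on the same sulfur would read in this assay remains open.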